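Pyridinyl for difluorophenyl at a benzylic position

The source may hold more compounds than are shown below. What is called first, only, known or untested is meant among the compounds shown, and "the series" means these compounds.

Measured compounds:
- compound 1 `O=c1c2ccccc2c(Nc2n[nH]c3ccccc23)nn1-c1ccccc1`: "not determined" (no result reported)
- compound 2 `Cc1cc(Nc2nn(Cc3cc(F)ccc3F)c(=O)c3ccccc23)n[nH]1`: > 30000 nM
- compound 3 `CC(=O)Nc1ccc(Cn2nc(Nc3cc(C)[nH]n3)c3ccccc3c2=O)cc1`: > 30000 nM

In a functional assay on MCF7 cells (Homo sapiens) for cytotoxicity (on this read-out higher numbers stand for weaker inhibition and lower numbers for stronger inhibition), compound 2 reaches only > 30000 nM, which is a limit of the assay and not a number. Compound 3 likewise stops at > 30000 nM, again a limit rather than a measured number. For compound 1 no result is reported. So compound 2 stands at the edge of what the assay can read; the limit of > 30000 nM in this assay, at which 2 of the 3 values shown sit, describes where it sits, and there is no measured number among the three to rank it against.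

Compound 4 `Cc1cc(Nc2nn(Cc3cccnc3)c(=O)c3ccccc23)n[nH]1` differs from compound 2 in one place: pyridin-3-yl in place of 2,5-difluorophenyl on a saturated chain carbon bound to an aromatic nitrogen. For the measured compounds named here, no step between two measured compounds is available, so the size of this change can only be guessed. Because compound 2 gives > 30000 nM and compound 3 gives > 30000 nM, both limits, the expectation is that compound 4 also stays at the limit, with no step beyond the scatter. Compound 4 is therefore expected to show 40000 nM, between 10000 nM and 150000 nM, which would mean a step that the limit leaves unreadable from compound 2 to compound 4.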

Compound 4, half-maximal inhibitory concentration: 13400 nM
The estimate for compound 4 lay 3.0-fold (0.47 log units) above the measured number; measured number inside the range.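

In this assay, compound 4 gives 13400 nM, the only measured number among the compounds shown. So this position can move the read-out off the limit of the assay. Putting pyridin-3-yl in place of 2,5-difluorophenyl on a saturated chain carbon bound to an aromatic nitrogen gives an at least 2.2-fold lower number from compound 2 to compound 4 (0.35 log units; beyond the scatter). The full size of this step cannot be read, since the value of compound 2 is a limit and not a number: the limit of > 30000 nM in this assay, at which 2 of the 4 values shown sit.

Going by these compounds, it remains open whether the change in the read-out goes with the ring nitrogen or with the loss of the two fluorine atoms, and a plain phenyl group at this place would help to separate the two. On these data alone, how pyridin-2-yl, pyridin-4-yl or a saturated ring amine such as piperidin-4-yl would read here also remains open.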